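Fluoro to Methyl on Compound 1: An Expected Outcome

The compounds below may be only part of what the source reports. "The series", "measured", "known", "first", "only" and "open" are said of these compounds alone.

Compound 1 `O=C(O)Cc1sc(C(c2ccc(F)cc2)c2ccc(F)cc2)nc1-c1ccnc(F)c1` and compound 2 `O=C(O)Cc1sc(C(c2ccccc2)c2ccccc2)nc1-c1cccc(F)c1` share a core. In an in vitro functional assay on HEK285-7 cells for antagonist activity at prostaglandin D2 receptor 2 (Homo sapiens), read by BRET and beta-arrestin recruitment (on this read-out higher numbers stand for larger maximal responses and lower numbers for smaller maximal responses), compound 1 gives 80%, and compound 2 gives 80%, so the two stand level within the usual scatter. Compound 3 `Cc1cc(-c2nc(C(c3ccc(F)cc3)c3ccc(F)cc3)sc2CC(=O)O)ccn1` differs from compound 1 in one place: methyl in place of fluoro on an aromatic carbon. Among the compounds with values here, no pair of measured compounds shows what this exchange does, so nothing here points to a shift in either direction beyond the scatter. Compound 3 is therefore expected to give about 80% in this assay, with a range from 62% to 98%, meaning an expected step of no change at the digits printed from compound 1 to compound 3 (within the scatter) that stays within the scatter.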

Compound 3, largest response reached (reported as efficacy), in percent of the reference or control that the assay uses: 80%
Estimate against measurement, compound 3: no gap at the digits printed; measured number inside the range.
By their numbers in this assay, from the lowest: compounds 1, 2 and 3 (each within the scatter of the next).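

In this assay, the change from 2-fluoropyridin-4-yl to 2-methylpyridin-4-yl gives no change at the digits printed from compound 1 to compound 3 (within the scatter) on the shared core. Within the data shown here, this is the first direct reading of this exchange, and it shows that, at this position next to the ring nitrogen, fluoro and methyl cannot be told apart on this read-out. That finding rests on this single pair and does not extend to other cores.

From the compounds shown here alone, whether an amine, a methoxy group or a longer chain in the same place would read the same stays open. No measurement at hand explains why fluoro and methyl read alike here.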